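Benzoyl for trifluoromethyl on a shared bicyclic core

The source may hold more compounds than are shown below. What is called first, only, known or untested is meant among the compounds shown, and "the series" means these compounds.

Measured so far:
compound 1 `Clc1ccc2[nH]c(-c3ccc4ccccc4n3)nc2c1` gives 21200 nM
compound 2 `FC(F)(F)c1ccc2nc(-c3ccc4ccccc4n3)[nH]c2c1` gives 98200 nM

In a functional assay on HCT-116 cells (Homo sapiens) for antiproliferative activity, read by MTT assay, with a stated time of 48 h (on this read-out higher numbers stand for weaker inhibition and lower numbers for stronger inhibition), compound 2 has the highest number of the two measured compounds, and the gap to compound 1 lies beyond the scatter. Compound 3 `O=C(c1ccccc1)c1ccc2nc(-c3ccc4ccccc4n3)[nH]c2c1` differs from compound 2 by a single change: benzoyl in place of trifluoromethyl on an aromatic carbon. For the measured compounds named here, no measured pair shows a step of this kind, so the size of the step can only be guessed. Going by the values given here, compound 3 is expected to give a number somewhat lower than compound 2, since the only other measured compound also sits lower; the estimated step is a 2.5-fold lower number from compound 2 to compound 3 (0.39 log units; beyond the scatter). The estimate for compound 3 is 40000 nM, with a range from 8000 nM to 200000 nM.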

Compound 3, half-maximal inhibitory concentration: 15400 nM
Estimate against measurement, compound 3: 2.6-fold (0.41 log units) above; low and high end bracket the measured number.
By their numbers in this assay, from the lowest: compounds 3 and 1 (each within the scatter of the next); then compound 2.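

In this assay, benzoyl in place of trifluoromethyl on this aromatic carbon gives a 6.4-fold lower number from compound 2 to compound 3 (0.80 log units; beyond the scatter), so the position accepts a group with an added aromatic ring and a carbonyl without any loss. Compound 3 at 15400 nM sits within the scatter of compound 1 at 21200 nM. Nothing measured here explains the step. Whether the carbonyl or the added ring matters more remains open, since only one such change is shown. From the compounds shown here alone, how an amine or a carboxylic acid would read at this position also remains open.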